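A Methylphenyl in Place of the Methylpyridyl

A few compounds are considered here, and "the series" means these few. Any claim that something is new, unique, unknown or untested is made for them only; others in the source may bear on it.

Compound 2 `Cc1cccc(-c2noc(C3CC(=O)N(c4ccc(Cl)cc4)C3)n2)n1` carries a 6-methylpyridin-2-yl group on the five-membered aromatic ring of the shared core. In an in vitro functional assay on HEK293-A cells for positive allosteric modulation of metabotropic glutamate receptor 5 (Homo sapiens), read by FLIPR and calcium flux (a lower number here means that less compound is needed, a higher number that more compound is needed for the effect), compound 2 gives only a limit, > 10000 nM, which is the limit of the assay and not a number (the limit of > 10000 nM in this assay, at which 1 of the 2 values shown sits). Compound 1 `O=C1CC(c2nc(-c3ccc(F)cc3)no2)CN1c1ccc(Cl)cc1`, which bears 4-fluorophenyl at the same place, gives 1700 nM in this assay. Within the data shown here, the step of an at least 5.8-fold higher number from compound 1 to compound 2 (0.76 log units; beyond the scatter) is thus the only measured change at this position, and it is at least modest.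

Compound 3 `Cc1cccc(-c2noc(C3CC(=O)N(c4ccc(Cl)cc4)C3)n2)c1` differs from compound 2 by 3-methylphenyl in place of 6-methylpyridin-2-yl on an aromatic carbon. The change therefore returns to a carbon-only six-membered ring, as in compound 1, though with a methyl instead of a fluorine on it. The step of an at least 5.8-fold higher number from compound 1 to compound 2 (0.76 log units; beyond the scatter) bears directly on this: exchanging the carbon-only ring for the pyridyl cost at least modest potency, so reversing the ring type is expected to recover part of it, with the methyl adding uncertainty. Compound 3 is therefore estimated at 3500 nM, with a range of 1000 nM to 10000 nM. That estimate corresponds to the step of an at least 2.8-fold lower number from compound 2 to compound 3 (0.45 log units; beyond the scatter).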

Compound 3, half-maximal effective concentration: 170 nM
Estimate against measurement, compound 3: 21-fold (1.31 log units) above, and the stated range ends above it.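

At this position on the five-membered aromatic ring, the pyridyl ring nitrogen gives way to a carbon while the methyl stays, and this single exchange gives an at least 58-fold lower number from compound 2 to compound 3 (1.76 log units; beyond the scatter), so the ring type alone can decide much of the result here. The earlier compounds shown here showed only a loss at this position, whereas a carbon-only ring with a methyl now goes past the 4-fluorophenyl group, with a 10-fold lower number from compound 1 to compound 3 (1.00 log units; beyond the scatter), so the substituent on a carbon-only ring also matters and the ring type is not the whole story. Compound 2 stands at a limit of the assay, so the size of its step to compound 3 is a bound and not a measured difference: the limit of > 10000 nM in this assay, at which 1 of the 3 values shown sits.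

The compounds shown do not separate the part played by the methyl from the part played by the missing fluorine, and they do not tell whether the position of either substituent on the ring matters. On these data alone, how an unsubstituted phenyl, a 4-methylphenyl or a 3-fluorophenyl would stand in this assay remains open.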